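The source may hold more compounds than are shown below. What is called first, only, known or untested is meant among the compounds shown, and "the series" means these compounds.

Measured so far in a functional assay on the whole organism for antagonist activity, with Mus musculus as the target, in the maximal electroshock model; on this read-out higher numbers stand for an effect only at larger amounts of compound and lower numbers for an effect already at smaller amounts:
Compound 1 `COC(=O)NC1=NC(c2ccccc2F)CN1`: 54 mg/kg
Compound 2 `COC(=O)NC1=NC(c2cccc(F)c2)CN1`: 70 mg/kg

These two compounds share the same core and carry a fluoro group on the aromatic ring, at different places. Compound 2, at 70 mg/kg, lies within the usual scatter of compound 1, at 54 mg/kg. Repeated measurements could give a gap of this size by chance, so the two cannot be told apart.

The next compound is compound 3 `COC(=O)NC1=NC(c2cccc(Br)c2)CN1`. It has bromo in place of fluoro on an aromatic carbon, meta to a large group: bromo in place of fluoro on an aromatic carbon. Going by the values given here, no measured compound carries bromo, and no measured pair shows what swapping one halogen for another does in this assay. Among the compounds with values here, the only guide is that compound 1 and compound 2 give similar doses, so no large step is assumed. The expected 1.3-fold lower number from compound 2 to compound 3 (0.10 log units; within the scatter) stays within the scatter, with no clear direction. For compound 3 the estimated dose is 55 mg/kg, with an expected range from 25 mg/kg to 120 mg/kg.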

Compound 3, dose for half-maximal effect: about 68 mg/kg
Beside the measured number, compound 3's estimate is 1.2-fold (0.09 log units) below it, within the range that was stated.
By their numbers in this assay, from the lowest: compounds 1, 3 and 2 (each within the scatter of the next).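

In this assay, the change of bromo in place of fluoro, on an aromatic carbon meta to a large group, gives a 1.0-fold lower number from compound 2 to compound 3 (0.01 log units; within the scatter), so compound 2 and compound 3 cannot be told apart. Going by these compounds alone, compound 1 and compound 2 differ only in where the fluoro sits, so this pair is the first to show what exchanging the halogen itself does at a fixed place: here, exchanging one halogen for the other leaves no difference that this read-out can resolve, and the result holds for this single place and this single pair of halogens. No measurement shown explains the closeness of the two doses.

Every ring substituent shown so far is a halogen, so it remains open whether a group of another kind at this place, such as an amine, a carboxylic acid or a longer chain, would also give a dose within the scatter of compound 2 or a clearly different one. From the compounds shown here alone, it also remains open whether bromo at the place the fluoro occupies in compound 1 would match that compound in the same way.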